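Swapping fluoro for 1,1-difluoroethyl on a thiazolidinone amide

The source may report more compounds than this note shows. Statements on the series, on what has been measured and on what is new or still open speak of the compounds shown alone.

Three compounds sharing the same core were tested in an ADME assay on microsomes from liver (Rattus norvegicus) for metabolic stability, read by LC-MS, using NADPH, with a stated time of 10 min, tested at 0.1 uM; on this read-out higher numbers stand for fast clearance and lower numbers for slow clearance. Compound 1 `CC1SC(c2cccc(C(=O)NCCCCc3ccccc3)c2)N(c2ccc(C3CC3)cc2)C1=O` gives 3130 mL.min-1.g-1. Compound 2 `O=C(NCCCCc1ccccc1)c1cccc(C2SCC(=O)N2c2cccc(F)c2)c1` gives 3240 mL.min-1.g-1, the highest of the three numbers, though its gap to compound 1 is within the usual scatter of the measurement, so the two cannot be told apart. Compound 3 `Cc1ccnc(N2C(=O)CSC2c2cccc(C(=O)NCCCCn3cccn3)c2)c1` gives 1020 mL.min-1.g-1, a gap to compound 2 that lies beyond the scatter, so compound 3 is cleared more slowly.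

Compound 4 `CC(F)(F)c1cccc(N2C(=O)CSC2c2cccc(C(=O)NCCCCc3ccccc3)c2)c1` has not yet been measured in this assay. It differs from compound 2 by 1,1-difluoroethyl in place of fluoro on an aromatic carbon, on an aromatic carbon of a six-membered aromatic ring of carbon only, meta to a large group. Among the measured compounds shown here, no measured pair shows this change, so the expected step of a 1.1-fold lower number from compound 2 to compound 4 (0.03 log units; within the scatter) is judged to stay within the scatter, in no firm direction. Compound 4 is therefore estimated to give about 3000 mL.min-1.g-1, with a range from 1500 mL.min-1.g-1 to 6000 mL.min-1.g-1.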

Compound 4, intrinsic clearance in microsomes: 2320 mL.min-1.g-1
Estimate against measurement, compound 4: 1.3-fold (0.11 log units) above; the range from low to high includes it.
By their numbers in this assay, from the lowest: compound 3; then compounds 4, 1 and 2 (each within the scatter of the next).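

This is the only pair shown that differs in one place, so it gives the first direct reading of a change on this six-membered aromatic ring, meta to a large group. In this assay, 1,1-difluoroethyl in place of fluoro gives a 1.4-fold lower number from compound 2 to compound 4 (0.15 log units; within the scatter), so the two compounds cannot be told apart, even though the entering group has 4 heavy atoms and the leaving group has 1. Nothing available bears on why this swap leaves the read-out within the scatter.

Going by these compounds, whether an amine, a methoxy group or a nitrile at this same place would move the number beyond the scatter stays open. Compound 3, at 1020 mL.min-1.g-1, differs from the others in more than one place, so its number cannot be traced to any single change.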